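A few compounds are considered here, and "the series" means these few. Any claim that something is new, unique, unknown or untested is made for them only; others in the source may bear on it.

In a functional assay on SW-620 cells (Homo sapiens) for cytotoxicity, read by MTT assay, with a stated time of 48 h (a lower number here means a stronger inhibitor, a higher number a weaker inhibitor), compound 3 `CCCCCCCCCCCCCCCCCCNC(=O)[C@@H](NC(=O)c1cccs1)[C@@H](C)O` gives 200000 nM. Compound 2 `CCCCCCCCCCCCCCCCCCNC(=O)[C@@H](NC(=O)c1ccccc1)[C@@H](C)O` gives 200000 nM, level with compound 3, and together they stand as the highest of the three numbers. The step of no change at the digits printed from compound 2 to compound 3 (within the scatter) shows that exchanging one small aromatic ring for another left the reading where it was. Compound 1 `CCCCCCCCCCCCCCNC(=O)[C@@H](NC(=O)c1nccc2ccccc12)[C@@H](C)O`, which carries the isoquinolin-1-yl group on a shorter chain, gives 30400 nM, the lowest number here. Compound 4 `CCCCCCCCCCCCCCCCCCNC(=O)[C@@H](NC(=O)c1nccc2ccccc12)[C@@H](C)O` differs from compound 3 by isoquinolin-1-yl in place of thiophen-2-yl on a carbonyl carbon. Within the data shown here, no measured step tests this exact change; the only measured step, no change at the digits printed from compound 2 to compound 3 (within the scatter), was within the scatter, and compound 1 differs from the others in two places at once. Because compound 1 gives 30400 nM with the same ring, a downward step is expected, a 3.3-fold lower number from compound 3 to compound 4 (0.52 log units; beyond the scatter). Compound 4 is therefore estimated at 60000 nM, with a range from 20000 nM to 200000 nM.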

Compound 4, half-maximal inhibitory concentration: 136000 nM
The estimate for compound 4 lay 2.3-fold (0.36 log units) below the measured number; measured number inside the range.
By their numbers in this assay, from the lowest: compound 1; then compounds 4, 2 and 3 (each within the scatter of the next).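

In this assay, the isoquinolin-1-yl ring on the carbonyl carbon, with its two fused rings, does not stand apart from the single rings on the longer chain (a 1.5-fold lower number from compound 3 to compound 4 (0.17 log units; within the scatter); a 1.5-fold lower number from compound 2 to compound 4 (0.17 log units; within the scatter)). With the isoquinolin-1-yl ring held fixed, the chain alone makes a difference beyond the scatter: butyl in place of hydrogen on the saturated chain gives a 4.5-fold higher number from compound 1 to compound 4 (0.65 log units; beyond the scatter). No measurement shown here explains either result.

Still open, as far as these compounds go, is whether an amine or a carboxylic acid on the ring would move the number. A chain shorter than that of compound 1 is also untested here.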